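From Methyl to Methoxy on the Aromatic Ring

A few compounds are considered here, and "the series" means these few. Any claim that something is new, unique, unknown or untested is made for them only; others in the source may bear on it.

Values measured so far in an ADME assay on Vero cells (Chlorocebus sabaeus) for cytotoxicity, read by MTT assay, with a stated time of 72 h (a higher number here means that more compound is needed for the effect, a lower number that less compound is needed), are these
Compound 1 `Cc1ccccc1C(=O)Nc1nc(-c2ccccn2)cs1` gives 6300 nM
Compound 2 `Cc1cccc(C(=O)Nc2nc(-c3ccccn3)cs2)c1` gives 4100 nM
Compound 3 `O=C(Nc1nc(-c2ccccn2)cs1)c1cccc(OCc2ccccc2)c1` gives 14400 nM

Compound 1 cannot be told apart from compound 2, as the step between them shows (a 1.5-fold lower number from compound 1 to compound 2 (0.19 log units; within the scatter)). Together they sit at the lower end of these three numbers, while compound 3 holds the highest.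

The next compound is compound 4 `COc1ccccc1C(=O)Nc1nc(-c2ccccn2)cs1`, which has methoxy in place of methyl on an aromatic carbon, ortho to a large group (methoxy in place of methyl on an aromatic carbon). Among the compounds with values here, no measured compound carries methoxy, so no step shows this exact change, and two steps bear on it only indirectly. Changing 2-methylphenyl to 3-methylphenyl left the number within the scatter, as already seen for compound 2. Replacing methyl with benzyloxy, a much bigger group than methoxy, gave compound 3 a modest rise (a 3.5-fold higher number from compound 2 to compound 3 (0.55 log units; beyond the scatter)). With a smaller swap than that one, a step within the scatter is expected in this assay, if anything slightly upward. The expected result is a small step (a 1.1-fold higher number from compound 1 to compound 4 (0.05 log units; within the scatter)). Compound 4 is estimated at 7000 nM with an expected range from 3000 nM to 16000 nM in this assay.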

Compound 4, half-maximal effective concentration: 43500 nM
The estimate for compound 4 lay 6.2-fold (0.79 log units) below the measured number; measured number outside the range, above it.
By their numbers in this assay, from the lowest: compounds 2 and 1 (each within the scatter of the next); then compound 3; then compound 4.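

In this assay, the exchange of methyl for methoxy on an aromatic carbon, ortho to a large group, gives a 6.9-fold higher number from compound 1 to compound 4 (0.84 log units; beyond the scatter) and so shows that this place responds to a change of only a few atoms, whereas the earlier shift of the methyl group, a 1.5-fold lower number from compound 1 to compound 2 (0.19 log units; within the scatter) and within the scatter, had suggested little sensitivity in this part of the molecule. The step is of the same modest class as a 3.5-fold higher number from compound 2 to compound 3 (0.55 log units; beyond the scatter) even though methoxy is much smaller than benzyloxy, so among these compounds the size of the entering group does not set the size of the step, and compound 4 now has the highest number of the four. No measurement shown here gives a reason for this rise.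

Still open, going by these compounds, is whether the rise follows the added oxygen, which brings one hydrogen-bond acceptor, or simply the extra heavy atom, something an ethyl group or a hydroxyl group at this same place could help separate. Also open, on these data alone, is whether methoxy in place of the methyl of compound 2 would give a similar step, or whether the effect belongs to this place alone.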